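Aryl swap on the benzylamino arm of the shared core

The compounds below may be only part of what the source reports. "The series", "measured", "known", "first", "only" and "open" are said of these compounds alone.

Working notes on a small set sharing one core. Compound 1 `Cc1cc(Nc2nc(Cl)nc3[nH]ncc23)n[nH]1` gives 5940 nM in an assay on isolated protein for inhibition of serine/threonine-protein kinase PAK 4 (Homo sapiens), read by HTRF, with a stated time of 60 min; on this read-out lower numbers stand for stronger inhibition and higher numbers for weaker inhibition. Compound 2 `Cc1cc(Nc2nc(NC3CCNC3)nc3[nH]ncc23)n[nH]1` gives 1050 nM; the step of a 5.7-fold lower number from compound 1 to compound 2 (0.75 log units; beyond the scatter). Compound 3 `Cc1cc(Nc2nc(NCc3cccc(F)c3)nc3[nH]ncc23)n[nH]1` gives 458 nM and thus holds the lowest number of the three, with the step of a 2.3-fold lower number from compound 2 to compound 3 (0.36 log units; beyond the scatter) and a wider gap back to compound 1.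

Compound 4 `Cc1cc(Nc2nc(NCc3ccc(Br)cc3)nc3[nH]ncc23)n[nH]1` is not yet measured. It differs from compound 3 by 4-bromophenyl in place of 3-fluorophenyl on a saturated chain carbon bound to a nitrogen on an aromatic ring; cut one bond further out, the change reads 3-fluorobenzyl to 4-bromobenzyl. Neither measured step bears directly on this: the step from compound 1 to compound 2 exchanges chloro for (pyrrolidin-3-yl)amino, and the step from compound 2 to compound 3 exchanges pyrrolidin-3-yl for 3-fluorobenzyl, so the aromatic ring of compound 3 is the only one of its kind in the set. Within the data shown here, no step here compares two different substituted phenyl groups on that saturated chain carbon.

With that, compound 4 is expected to stay close to compound 3, a step of a 1.0-fold lower number from compound 3 to compound 4 (0.01 log units; within the scatter) that is not expected to exceed the scatter. Compound 4 is estimated at 450 nM, with a range from 180 nM to 1200 nM.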

Compound 4, half-maximal inhibitory concentration: 1320 nM
For compound 4 the middle estimate is 2.9-fold (0.47 log units) below the measured one; measured number outside the range, above it.
By their numbers in this assay, from the lowest: compound 3; then compounds 2 and 4 (each within the scatter of the next); then compound 1.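

Among these compounds, this is the first comparison of two substituted phenyl groups on a saturated chain carbon bound to a nitrogen on an aromatic ring, and in this assay the exchange of 3-fluorophenyl for 4-bromophenyl gives a 2.9-fold higher number from compound 3 to compound 4 (0.46 log units; beyond the scatter) and so shows that the number at this position depends on the aryl group and not merely on the presence of a benzyl arm. The step beyond the scatter seen with 3-fluorobenzyl in place of pyrrolidin-3-yl does not hold for every benzyl group, as 4-bromobenzyl in that same place gives a 1.3-fold higher number from compound 2 to compound 4 (0.10 log units; within the scatter) and stays within the scatter. Nothing available here explains the difference between the two aryl groups.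

The two aryl groups differ at once in the halogen and in its place on the ring, and the compounds shown do not separate these two changes. Also open, as far as these compounds go, is how the number responds to an unsubstituted phenyl on the same saturated chain carbon, or to a phenyl carrying a methoxy group, an amine or a carboxylic acid.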